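Nitro in place of methylsulfonyl on the compound 3 scaffold

The compounds below may be only part of what the source reports. "The series", "measured", "known", "first", "only" and "open" are said of these compounds alone.

Measured so far:
compound 1 `CS(=O)(=O)c1ccc(C(=O)N2CCC(n3cncc3-c3ccc(OS(=O)(=O)c4cccc5cnccc45)cc3)CC2)cc1`: 0.32 nM
compound 2 `CN(C)c1ccc(C(=O)N2CCC(n3cncc3-c3ccc(OS(=O)(=O)c4cccc(C(=O)NC5CC5)c4)cc3)CC2)cc1`: 1.03 nM
compound 3 `CS(=O)(=O)c1ccc(C(=O)N2CCN(c3cc(=O)[nH]c(=O)n3Cc3ccc(OS(=O)(=O)c4cccc5cnccc45)cc3)CC2)cc1`: 50 nM

All three numbers come from an assay on THP-1 cells for antagonist activity at P2X purinoceptor 7 (Homo sapiens), read by ELISA, with a stated time of 30 min; on this read-out lower numbers stand for stronger inhibition and higher numbers for weaker inhibition. Compound 1 gives 0.32 nM and compound 2 gives 1.03 nM; compound 3, with its different core, gives 50 nM, the highest of the three numbers, beyond the scatter above both others. The nearest value is that of compound 2, the furthest that of compound 1. Compound 3 therefore stands as the weakest inhibitor among the measured compounds.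

Compound 4 `O=C(c1ccc([N+](=O)[O-])cc1)N1CCN(c2cc(=O)[nH]c(=O)n2Cc2ccc(OS(=O)(=O)c3cccc4cnccc34)cc2)CC1` keeps the core of compound 3 and differs from it in one place: nitro in place of methylsulfonyl on an aromatic carbon. Going by the values given here, no measured pair shows this change, so its effect is not known from the numbers at hand. Both groups carry the same count of hydrogen-bond acceptors and no donor, and the change sits far from the sulfonate part of the molecule. The step of no change at the digits printed from compound 3 to compound 4 (within the scatter) in this assay is expected to be small and in no clear direction, within the scatter. For compound 4 the estimated value in this assay is 50 nM, with an expected range from 15 nM to 160 nM.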

Compound 4, half-maximal inhibitory concentration: 32 nM
Compound 4: the middle estimate sits 1.6-fold (0.19 log units) above what was measured, and the stated range covers the measured number.
By their numbers in this assay, from the lowest: compound 1; then compound 2; then compounds 4 and 3 (each within the scatter of the next).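

In this assay, going by these compounds alone, the only matched pair at this position gives a 1.6-fold lower number from compound 3 to compound 4 (0.19 log units; within the scatter), so 4-(methylsulfonyl)phenyl and 4-nitrophenyl cannot be told apart on the core of compound 3. Within the data shown here, compounds 1 to 3 offered no pair differing in one place, so this is the first direct reading of any single change, and it shows that on this core the methylsulfonyl group can give way to nitro, on an aromatic carbon para to a large group, without a change beyond the scatter. The reading rests on one pair and one assay, and nothing available explains why the two groups read alike.

Open is whether the same exchange would behave alike on the core of compound 1, which also carries methylsulfonyl at this place but has no nitro partner among the compounds shown. Also open, on these data alone, is how far this tolerance extends to groups of another kind at the same carbon, such as a primary amine, a carboxylic acid or plain hydrogen.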